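The source may report more compounds than this note shows. Statements on the series, on what has been measured and on what is new or still open speak of the compounds shown alone.

Measured so far:
- compound 1, `CCOCCOn1c(-c2cccc(C#N)c2)nc(C)c1C(=O)OCC`: 6250 nM
- compound 2, `CCOC(=O)c1c(C)nc(-c2cccc(C#N)c2)n1OCc1ccc(Br)cc1`: 24600 nM

In a functional assay on a cell-free system (plasma, Oryctolagus cuniculus) for inhibition, with stated times of 5 min, 1 min and 6 min (a lower number here means a stronger inhibitor, a higher number a weaker inhibitor), compound 1 gives the lowest of the two numbers, so it is the stronger inhibitor of the pair. For the measured compounds named here, the one measured step, a 3.9-fold higher number from compound 1 to compound 2 (0.60 log units; beyond the scatter), is modest but beyond the scatter. Compound 3, `CCOC(=O)c1c(C)nc(-c2cccc(C#N)c2)n1OCc1ccc(C#N)cc1`, differs from compound 1 by 4-cyanophenyl in place of ethoxymethyl on a saturated chain carbon bound to an oxygen on an aromatic ring. Compound 3 carries, like compound 2, an aromatic ring in place of the ethoxymethyl, so a weakening of similar size is expected, about a 2.7-fold higher number from compound 1 to compound 3 (0.43 log units; beyond the scatter). Compound 3 is therefore estimated at 17000 nM, within 6000 nM to 50000 nM.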

Compound 3, half-maximal inhibitory concentration: 4240 nM
Beside the measured number, compound 3's estimate is 4.0-fold (0.60 log units) above it; the whole stated range lies above it.
By their numbers in this assay, from the lowest: compounds 3 and 1 (each within the scatter of the next); then compound 2.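

In this assay an aromatic ring at this place need not weaken inhibition: 4-cyanobenzyl in place of 2-ethoxyethyl gives a 1.5-fold lower number from compound 1 to compound 3 (0.17 log units; within the scatter) and so stays level with the ether chain. The group on that ring counts, for cyano in place of bromo on an aromatic carbon gives a 5.8-fold lower number from compound 2 to compound 3 (0.76 log units; beyond the scatter) with the rest of the compound unchanged. No measurement at hand explains this difference.

Still open, on these data alone, is how an amine or a carboxylic acid on that aromatic ring would compare. A longer chain in place of 2-ethoxyethyl also remains to be seen.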